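This account rests on a few compounds, and the source may have more. Where it says the series, first, only, none or still open, it means among the compounds named here.

Compound 1 `COc1cc(-c2ccnc3cc(-c4ccc(F)cc4)nn23)cc(OC)c1OC` was tested in a functional assay on B16-F0 cells (Mus musculus) for inhibition, read by CCK-8 assay, with a stated time of 48 h (on this read-out higher numbers stand for weaker inhibition and lower numbers for stronger inhibition), where compound 1 gives 4540 nM. Among the compounds with values here, its only measured companion is compound 2 `COc1cc(-c2ccnc3cc(-c4ccc5cnn(C)c5c4)nn23)cc(OC)c1OC`, which in this assay gives 1000 nM. Within the data shown here, the one recorded step, a 4.5-fold lower number from compound 1 to compound 2 (0.66 log units; beyond the scatter), exchanges the whole aromatic ring that carries the fluoro for a different ring system. On the numbers at hand, compound 1 therefore stands with the highest number of the two, the weaker inhibitor.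

Compound 3 `CCOC(=O)c1ccc(-c2cc3nccc(-c4cc(OC)c(OC)c(OC)c4)n3n2)cc1` has not yet been measured in this assay. It differs from compound 1 at a single point: ethoxycarbonyl in place of fluoro on an aromatic carbon. Among the measured compounds shown here, no measured step bears directly on this change, since the step from compound 1 to compound 2 replaced the entire ring rather than swapping one group on it. For the measured compounds named here, with only that indirect step, there is no basis for expecting a shift beyond the scatter in either direction, though a modest movement either way cannot be ruled out.

Compound 3 is therefore estimated at 3500 nM, with a plausible range from 900 nM to 14000 nM, which would mean an expected step of a 1.3-fold lower number from compound 1 to compound 3 (0.11 log units; within the scatter).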

Compound 3, half-maximal inhibitory concentration: > 10000 nM
Compound 3 was reported as a limit (the forecaster's own chance of this, stated with the estimate: 10%); middle value at least 2.8-fold (0.45 log units) away from the limit.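

Within the data shown here, the step from fluoro to ethoxycarbonyl is the first look at a single group changing on this ring, at the place para to a large group, while the ring itself stays; the earlier step swapped the entire ring. The change gives an at least 2.2-fold higher number from compound 1 to compound 3 (0.34 log units; beyond the scatter), so this place does not accept every group without a cost, and inhibition weakens, in the opposite direction to the ring exchange. Compound 3 is reported in this assay only as a limit, not as a number, so its step has a lower bound but no known size: the limit of > 10000 nM in this assay, at which 1 of the 3 values shown sits.

The entering ethoxycarbonyl differs from fluoro in several ways at once, with 5 heavy atoms against 1, a double bond outside the aromatic rings and 2 hydrogen-bond acceptors against 0, and these two compounds cannot show which of these differences matters. As far as these compounds go, whether a methoxy group, a carboxylic acid or a primary amide at the same place would keep the inhibition of compound 1 or lose it as well remains open, as does whether a shorter methyl ester would behave like the ethyl ester.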